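The source may report more compounds than this note shows. Statements on the series, on what has been measured and on what is new or still open speak of the compounds shown alone.

The shared core carries on an amide-type nitrogen a side arm and a further group that changes through the series; compound 1 `COC(=O)c1ccc(N(Cc2cnc(C3CCCCC3)cn2)C(=O)[C@H]2CCN2S(=O)(=O)c2c(F)c(F)c(F)c(F)c2F)c(F)c1` is one member, compound 2 `O=C1OCc2cc(N(Cc3ccc(C4CCCCC4)cn3)C(=O)[C@H]3CCN3S(=O)(=O)c3c(F)c(F)c(F)c(F)c3F)ccc21` another, and compound 3 `O=C(NO)c1ccc(N(Cc2cnc(C3CCCCC3)cn2)C(=O)[C@H]2CCN2S(=O)(=O)c2c(F)c(F)c(F)c(F)c2F)c(F)c1` a third. In a functional assay on MDA-MB-231 cells (Homo sapiens) for antiproliferative activity, with a stated time of 72 h (a higher number here means that more compound is needed for the effect, a lower number that less compound is needed), compound 1 gives 1400 nM. In this assay compound 2 gives 900 nM; of the two numbers at hand this is the lower one, yet its gap to compound 1 lies within the usual scatter, so the two cannot be told apart. In this assay compound 3 gives "not determined" (no result reported), so no number is at hand for it. Compound 4 `Cn1ccc2cc(N(Cc3ccc(C4CCCCC4)cn3)C(=O)[C@H]3CCN3S(=O)(=O)c3c(F)c(F)c(F)c(F)c3F)ccc2c1=O` has not yet been measured. It differs from compound 2 by a group of 12 heavy atoms (10 carbon, 1 nitrogen, 1 oxygen; one six-membered aromatic ring of carbon only, one six-membered aromatic ring with 1 hetero atom) in place of a group of 10 heavy atoms (8 carbon, 2 oxygen; one five-membered non-aromatic ring with 1 hetero atom, one six-membered aromatic ring of carbon only), on an amide-type nitrogen. Among the compounds with values here, no step between two measured compounds bears on this change, so nothing in the data says in which direction, if any, it should move the number. Within the data shown here, because compound 2 gives 900 nM and the only other number, that of compound 1 at 1400 nM, sits within the scatter of it, the series so far spans a narrow band. Compound 4 is therefore expected to stay near that band, with an expected step of no change at the digits printed from compound 2 to compound 4 (within the scatter) no larger than the scatter in either direction. Compound 4 is estimated at 900 nM, within a range from 300 nM to 3000 nM.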

Compound 4, half-maximal effective concentration: 2300 nM
The estimate for compound 4 lay 2.6-fold (0.41 log units) below the measured number; the range from low to high includes it.
By their numbers in this assay, from the lowest: compounds 2, 1 and 4 (each within the scatter of the next, the first and the last beyond it).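

Within the data shown here, on an amide-type nitrogen, the group with one six-membered aromatic ring of carbon only and one six-membered aromatic ring with 1 hetero atom, in place of the group with one five-membered non-aromatic ring with 1 hetero atom and one six-membered aromatic ring of carbon only, gives a 2.6-fold higher number from compound 2 to compound 4 (0.41 log units; beyond the scatter) in this assay and is the first step that can be read at this place. It shows that the number responds to the group held on this nitrogen, although only modestly, and that such a step can arise with no difference in the counts of hydrogen-bond donors, hydrogen-bond acceptors, double bonds outside aromatic rings or net charge. Nothing at hand accounts for the step, so it stands as an observation without an explanation.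

The compounds shown leave open whether a simple phenyl ring carrying a carboxylic acid or a primary amine on this nitrogen would give a lower or a higher number than either group compared here. Among these compounds, they also leave open whether the same exchange would give a step of similar direction and size with the side arm of compound 1 in place of the one shared by compound 2 and compound 4.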